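Nitro for methyl on the pyridine ring

The compounds below may be only part of what the source reports. "The series", "measured", "known", "first", "only" and "open" are said of these compounds alone.

Compound 1 `O=C(O)c1cccc(-c2ccc(/C=C3\S/C(=N\c4ccccc4)N(c4ccc(F)cc4)C3=O)s2)c1` in an ADME assay on Vero cells (Chlorocebus sabaeus) for cytotoxicity (on this read-out lower numbers stand for higher toxicity in this test and higher numbers for lower toxicity in this test), reaches only a limit of the assay, > 200000 nM. Compound 2 `Cc1ncccc1N1C(=O)/C(=C/c2ccc(-c3cccc(C(=O)O)c3)s2)S/C1=N\c1ccccc1` in this assay likewise reaches only a limit, > 200000 nM. The step that the two limits leave unreadable from compound 1 to compound 2 is therefore unreadable; the limit of > 200000 nM in this assay, at which 2 of the 2 values shown sit, is the whole evidence, and compound 2 stands on that limit without a number of its own. Compound 3 `O=C(O)c1cccc(-c2ccc(/C=C3\S/C(=N\c4ccccc4)N(c4cccnc4[N+](=O)[O-])C3=O)s2)c1` carries nitro in place of methyl on an aromatic carbon. Within the data shown here, no measured step shows how such a change moves this assay. The expectation for compound 3 is 200000 nM, between 50000 nM and 600000 nM. The expected step of a number no higher from compound 2 to compound 3 (the limit leaves the size open) most likely leaves the read-out at the limit again.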

Compound 3, half-maximal cytotoxic concentration: > 200000 nM
Compound 3 ended at the assay's limit; the forecaster's own chance of this, stated with the estimate: 80%; the middle value sits exactly at the limit.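

No step can be read among compound 1, compound 2 and compound 3 in this assay, as all three values are limits of the assay and not numbers: the limit of > 200000 nM in this assay, at which 3 of the 3 values shown sit.

The compounds shown leave open whether the methyl, nitro and 4-fluorophenyl changes differ at all in half-maximal cytotoxic concentration.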